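The source may report more compounds than this note shows. Statements on the series, on what has been measured and on what is new or still open speak of the compounds shown alone.

Of the compounds shown here, two have so far been measured in a functional assay on HCT-116 cells (Homo sapiens) for inhibition, read by MTT assay, with a stated time of 2 days; a higher number here means a weaker inhibitor of growth, a lower number a stronger inhibitor of growth. Compound 1 `Nc1ccccc1NC(=O)c1ccc(NCC(=O)Nc2cccc([N+](=O)[O-])c2)cc1` gives 9000 nM. For the measured compounds named here, compound 2 `COc1ccc(NC(=O)CNCCCC(=O)Nc2ccccc2N)cc1` gives 44000 nM, the higher of the two numbers and therefore the weaker inhibitor of growth; its only neighbour is compound 1, whose number is lower by a margin beyond the usual scatter. Going by the values given here, no two measured compounds differ in a single place, so no measured step is available to lean on. Compound 3 `Nc1ccccc1NC(=O)CCCNCC(=O)Nc1cc(Cl)ccc1Cl` has not yet been measured. It differs from compound 2 in one place: 2,5-dichlorophenyl in place of 4-methoxyphenyl on an amide-type nitrogen. Among the compounds with values here, since the only other compound is altered elsewhere, the effect of this change cannot be read from the data. In this assay the change is expected to give a modest step toward a lower number, possibly not beyond the scatter: a 1.8-fold lower number from compound 2 to compound 3 (0.25 log units; within the scatter). Compound 3 is therefore estimated at 25000 nM, with a likely range from 8000 nM to 70000 nM.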

Compound 3, concentration for total growth inhibition: 78000 nM
Estimate against measurement, compound 3: 3.1-fold (0.49 log units) below; measured number above the stated range.
By their numbers in this assay, from the lowest: compound 1; then compounds 2 and 3 (each within the scatter of the next).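

In this assay, for the compounds shown here, the first measured change at this amide-type nitrogen gives a 1.8-fold higher number from compound 2 to compound 3 (0.25 log units; within the scatter), so this pair shows no difference that can be told apart from repeat measurement. Here, 2,5-dichlorophenyl serves in place of 4-methoxyphenyl without a clear change in the number, although a single pair cannot establish a wider pattern. Nothing measured bears on why the two compounds read alike.

On these data alone, it remains open whether a plain phenyl, a benzyl group or a short alkyl chain on this nitrogen would move the number beyond the scatter. Going by these compounds alone, compound 1 differs from compound 2 and compound 3 in more than one place, so no step to it can be read.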